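Chloro at a second place on the benzyl ring

The source may hold more compounds than are shown below. What is called first, only, known or untested is meant among the compounds shown, and "the series" means these compounds.

Compound 1 `COc1ccc(C2N=C(SCc3ccccc3)NC(C)=C2C(=O)Nc2ccc(F)cc2)cc1OC` in a functional assay on the whole organism (artery, strain albino) with Rattus norvegicus as the target, with a stated time of 240 min, at a dose of 10 mg/kg by the oral route (a lower number here means less inhibition, a higher number more inhibition at the dose given (going by the name of the read-out)), gives 11.8%.
Compound 2 `COc1ccc(C2N=C(SCc3ccc(Cl)cc3)NC(C)=C2C(=O)Nc2ccc(F)cc2)cc1OC` in this assay gives 24.1%.
Compound 3 `CC1=C(C(=O)Nc2ccc([N+](=O)[O-])cc2)C(c2cccc([N+](=O)[O-])c2)N=C(SCc2ccccc2)N1` in this assay gives 21%.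

Compound 1 and compound 2 share a core and differ by chloro in place of hydrogen on an aromatic carbon, a change placed para to a large group. That change gave a number 12.3 percentage points higher from compound 1 to compound 2 (beyond the scatter). Compound 3 carries a different core; the difference between the two cores is not broken down here. Its value in this assay lies within the scatter of both compound 1 and compound 2.

Compound 4 `CC1=C(C(=O)Nc2ccc([N+](=O)[O-])cc2)C(c2cccc([N+](=O)[O-])c2)N=C(SCc2ccccc2Cl)N1` has not yet been tested. Among the compounds with values here, it differs from compound 3 by chloro in place of hydrogen on an aromatic carbon, placed ortho to a large group, so it is the same kind of change as the one from compound 1 to compound 2, but not the same, and it sits on a different core. Within the data shown here, with only one earlier example, and that at a different place on the ring, a smaller step is expected for a number 5 percentage points higher from compound 3 to compound 4 (within the scatter) in this assay. Compound 4 is thus estimated at 26%, with a range from 12% to 40%.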

Compound 4, a percentage reported as inhibition, in the whole organism at one dose (the size of the read-out at that dose, not a potency): 12.8%
Estimate against measurement, compound 4: 13.2 percentage points above; measured number inside the range.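

On the second core, chloro in place of hydrogen, ortho to a large group, gave a number 8.2 percentage points lower from compound 3 to compound 4 (within the scatter) in this assay. This step cannot be told apart from no change, so it does not show that chloro harms the result on this core, and the two pairs also differ in where the chloro sits, which leaves the effect of the core and the effect of the place on the ring unseparated. What the data do show is that the gain seen on the first core cannot simply be assumed on the second, since the two steps do not agree: the same change on two cores in this assay, a number 12.3 percentage points higher (beyond the scatter) from compound 1 to compound 2 and a number 8.2 percentage points lower (within the scatter) from compound 3 to compound 4, 20.5 percentage points apart, beyond the scatter of two such steps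

The compounds shown leave open whether the 2-chlorobenzyl group would behave on the core of compound 1 as it does on the core of compound 3, and whether chloro at the place it holds in compound 2 would carry over to the core of compound 3. They also leave open what a bromo or an amine on the benzyl ring would give on either core.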